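Shrinking the sulfur substituent: from chlorobenzyl to ethynyl

The source may report more compounds than this note shows. Statements on the series, on what has been measured and on what is new or still open speak of the compounds shown alone.

Measured compounds:
compound 1 `Cc1cc(N2CC[C@@H](C)[C@@H](N(C)c3ncnc4[nH]ccc34)C2)n2nc(SCC3CCCCC3)nc2n1` — 9170 nM
compound 2 `Cc1cc(N2CC[C@@H](C)[C@@H](N(C)c3ncnc4[nH]ccc34)C2)n2nc(SCc3ccc(C(F)(F)F)cc3)nc2n1` — 2680 nM
compound 3 `Cc1cc(N2CC[C@@H](C)[C@@H](N(C)c3ncnc4[nH]ccc34)C2)n2nc(SCc3ccc(Cl)cc3)nc2n1` — 16000 nM

All three share one core and differ only in the group attached to the sulfur. In a functional assay on MGC-803 cells (Homo sapiens) for inhibition, read by MTT assay, with a stated time of 72 h (a lower number here means a stronger inhibitor, a higher number a weaker inhibitor), compound 3 has the highest number of the three. Its gap to compound 1 is small: a 1.7-fold higher number from compound 1 to compound 3 (0.24 log units; within the scatter). Its gap to compound 2 is larger: a 6.0-fold higher number from compound 2 to compound 3 (0.78 log units; beyond the scatter). Between compound 1 and compound 2 the step is a 3.4-fold lower number from compound 1 to compound 2 (0.53 log units; beyond the scatter).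

Compound 4 `C#CSc1nc2nc(C)cc(N3CC[C@@H](C)[C@@H](N(C)c4ncnc5[nH]ccc45)C3)n2n1` is not yet measured. The change from compound 3 is ethynyl in place of 4-chlorobenzyl on a sulfur. The three measured steps all keep a saturated chain carbon on the sulfur and vary what sits on it, so none of them covers removing that carbon and its ring and putting a two-carbon ethynyl in its place. Among the measured compounds shown here, they show only that swapping the group on the sulfur moves this assay modestly in either direction. Compound 4 is therefore expected to give 20000 nM, within 5000 nM to 60000 nM, a step of a 1.3-fold higher number from compound 3 to compound 4 (0.10 log units; within the scatter) that may not exceed the scatter.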

Compound 4, half-maximal inhibitory concentration: 18100 nM
The estimate for compound 4 lay 1.1-fold (0.04 log units) above the measured number; low and high end bracket the measured number.
By their numbers in this assay, from the lowest: compound 2; then compounds 1, 3 and 4 (each within the scatter of the next).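

In this assay, the ethynyl group, with no ring, sits level with the far larger 4-chlorobenzyl group on the sulfur (a 1.1-fold higher number from compound 3 to compound 4 (0.05 log units; within the scatter)). It also sits level with the cyclohexylmethyl group of compound 1 (a 2.0-fold higher number from compound 1 to compound 4 (0.30 log units; within the scatter)), so among these compounds a ring on the sulfur is not required to reach this level, and only the 4-(trifluoromethyl)benzyl group of compound 2 stands apart (a 6.8-fold higher number from compound 2 to compound 4 (0.83 log units; beyond the scatter)). No measurement shown gives a reason for this pattern.

Still open, from the compounds shown here alone, is whether trifluoromethyl itself sets compound 2 apart, which a benzyl group carrying a nitrile or a methoxy group in place of the trifluoromethyl could test. Going by these compounds, it is also open how a plain methyl, a longer chain or a chain ending in an amine on the sulfur would compare with ethynyl.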